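This account rests on a few compounds, and the source may have more. Where it says the series, first, only, none or still open, it means among the compounds named here.

Measured so far in a functional assay on K562 cells (Homo sapiens) for antiproliferative activity, read by fluorescence, with a stated time of 3 days; a lower number here means a stronger inhibitor, a higher number a weaker inhibitor:
- compound 1 (`CCCCCSc1nc(OC(=O)CC(C)(C)C)c2cn[nH]c2n1`) with 19800 nM as its value
- compound 2 (`O=[N+]([O-])c1cccc(Nc2nc(SCCc3ccccc3)nc3[nH]ncc23)c1`) with 19900 nM as its value

These two values lie within the scatter of each other, so compound 1 stands level with compound 2 on these numbers. Compound 3 (`CCCCCSc1nc(OC(=O)c2ccccc2)c2cn[nH]c2n1`) keeps the core of compound 1 but has phenyl in place of neopentyl on a carbonyl carbon. Within the data shown here, no measured pair shows this change, so no step beyond the scatter is expected. The estimated change (a 1.2-fold lower number from compound 1 to compound 3 (0.09 log units; within the scatter)) therefore stays small and has no firm direction. For compound 3 the expected value is 16000 nM, with an estimated range from 6000 nM to 40000 nM in this read-out.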

Compound 3, half-maximal inhibitory concentration: 19800 nM
Estimate against measurement, compound 3: 1.2-fold (0.09 log units) below; the measured number falls inside the stated range.
By their numbers in this assay, from the lowest: compounds 1, 3 and 2 (each within the scatter of the next).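

On a carbonyl carbon, phenyl in place of neopentyl gives no change at the digits printed from compound 1 to compound 3 (within the scatter) in this assay. This is the first pair among the compounds shown that differs in one place, and it shows that benzoyl and neopentylcarbonyl stand level here, with or without a six-membered aromatic ring at this position. No outside evidence bears on this result.

On these data alone, it remains open whether an amine, a carboxylic acid or a longer chain on this carbonyl carbon would move the number beyond the scatter. Compound 2 differs from both in more than one place, so it cannot settle that question.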